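The source may report more compounds than this note shows. Statements on the series, on what has been measured and on what is new or still open speak of the compounds shown alone.

Measured compounds, with their values in an assay on isolated protein for inhibition of Rho-associated protein kinase 2 (Homo sapiens); on this read-out lower numbers stand for stronger inhibition and higher numbers for weaker inhibition:
Compound 1, `COc1cccc(CNC(=O)c2cn(C)c3nc(-c4cn[nH]c4)ccc23)c1`, gives < 1 nM, which is a limit of the assay and not a number.
Compound 2, `COc1cccc(CNC(=O)c2c[nH]c3cc(-c4cn[nH]c4)ccc23)c1`, gives < 1 nM, again a limit rather than a number.

Compound 2 therefore stands at the limit of < 1 nM in this assay, at which 2 of the 2 values shown sit. Both values shown are limits. Neither compound can be placed above or below the other, and no measured step exists between any pair of these compounds.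

Compound 3, `COc1cccc(CN(C)C(=O)c2c[nH]c3cc(-c4cn[nH]c4)ccc23)c1`, differs from compound 2 only in methyl in place of hydrogen on an amide-type nitrogen. The amide hydrogen is replaced by a small carbon group and everything else in the molecule stays the same. Within the data shown here, no step of this kind has been measured here, so the expectation rests on the size of the change alone: a loss of potency, that is a rise in the number, is expected, somewhat beyond the usual scatter, with the true starting point of compound 2 itself unknown. The expected step is an at least 5.0-fold higher number from compound 2 to compound 3 (0.69 log units; beyond the scatter), towards weaker inhibition. Compound 3 is accordingly estimated at 5 nM, with a range from 0.5 nM to 50 nM.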

Compound 3, half-maximal inhibitory concentration: 2 nM
For compound 3 the middle estimate is 2.5-fold (0.40 log units) above the measured one, within the range that was stated.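

In this assay compound 3 gives 2 nM, the only value shown that is a number and not a limit, so inhibition remains in the low range shown here with a methyl in place of hydrogen on this amide-type nitrogen. The change gives an at least 2.0-fold higher number from compound 2 to compound 3 (0.30 log units; that floor lies within the scatter), which means that the amide hydrogen is not needed to reach this level of inhibition, while a real loss from adding the methyl can be neither confirmed nor ruled out. The true step could be larger than this floor because compound 2 is held at a limit of the assay and not at a number: the limit of < 1 nM in this assay, at which 2 of the 3 values shown sit.

From the compounds shown here alone, what remains open is how much bulk this amide-type nitrogen can carry, for instance whether an ethyl group, a longer chain or a chain ending in an amine would keep inhibition at this level. Going by these compounds, it is also open whether the same methyl would have a similar result on the core of compound 1, since a change on one core need not carry over to another.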